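Swapping a Pyrazine for a Fluoropyridine in a Cytotoxicity Series

The source may hold more compounds than are shown below. What is called first, only, known or untested is meant among the compounds shown, and "the series" means these compounds.

Of the compounds shown here, three have been tested in an ADME assay on HepG2 2.2.15 cells (Homo sapiens) for cytotoxicity; on this read-out lower numbers stand for stronger inhibition and higher numbers for weaker inhibition. Compound 1 `O=C1CCCC2=C1C(c1ccc(F)cc1Cl)N=C(c1cnccn1)N2` and compound 2 `O=C1CCCC2=C1C(c1ccc(F)cc1Cl)N=C(c1ncccc1F)N2` share one core; in this assay compound 1 gives 777000 nM and compound 2 gives 1370000 nM. For the measured compounds named here, the single change between them is pyrazin-2-yl in place of 3-fluoropyridin-2-yl on a carbon with a double bond to nitrogen, and it produced a 1.8-fold lower number from compound 2 to compound 1 (0.25 log units; within the scatter). Compound 3 `CC1(C)CC(=O)C2=C(C1)NC(c1ncccc1F)=NC2c1ccc(F)cc1Cl` is built on a different core, and in this assay compound 3 gives 371000 nM, the lowest of the three numbers. How the core of compound 3 differs from the core of compound 2 is not broken down here. Compound 4 `CC1(C)CC(=O)C2=C(C1)NC(c1cnccn1)=NC2c1ccc(F)cc1Cl` has not yet been measured. Going by the values given here, it differs from compound 3 by pyrazin-2-yl in place of 3-fluoropyridin-2-yl on a carbon with a double bond to nitrogen, the same change, at the same place, as the one seen between compound 2 and compound 1. Because the earlier step was a 1.8-fold lower number from compound 2 to compound 1 (0.25 log units; within the scatter), a step of similar size is expected here, a 1.7-fold lower number from compound 3 to compound 4 (0.23 log units; within the scatter), although this rests on a single example in a different core. The expected number for compound 4 in this assay is 220000 nM, likely between 110000 nM and 480000 nM.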

Compound 4, half-maximal inhibitory concentration: 773000 nM
Compound 4: the middle estimate sits 3.5-fold (0.55 log units) below what was measured; measured number above the stated range.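

Putting pyrazin-2-yl in place of 3-fluoropyridin-2-yl on the core of compound 3 gave a 2.1-fold higher number from compound 3 to compound 4 (0.32 log units; beyond the scatter) in this assay, so the earlier result did not carry over to this core. Set side by side, the two steps disagree: the same change on two cores in this assay, a 1.8-fold lower number (0.25 log units; within the scatter) from compound 2 to compound 1 and a 2.1-fold higher number (0.32 log units; beyond the scatter) from compound 3 to compound 4, 3.7-fold (0.57 log units) apart, beyond the scatter of two such steps. This shows that the outcome of this change depends on the core, at least for these two cores, but it does not show why, and with a single pair on each core it offers no rule for predicting the step on a third core.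

The compounds shown leave open how other groups at this place would behave on either core, such as a plain phenyl ring, a pyrimidine or an amine. Going by these compounds, it also remains open whether the two cores would still respond differently if an unsubstituted phenyl group replaced the 2-chloro-4-fluorophenyl group.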